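This account rests on a few compounds, and the source may have more. Where it says the series, first, only, none or still open, it means among the compounds named here.

In a physicochemical assay for lipophilicity (on this read-out lower numbers stand for lower lipophilicity and higher numbers for higher lipophilicity), compound 2 `CCOC[C@H](Oc1ncnc2c1cnn2-c1ncccc1Cl)C(=O)Nc1ccc(Cl)cn1` gives 3, the lower of the two numbers, while compound 1 `CC(C)OC[C@H](Oc1ncnc2c1cnn2-c1ncccc1Cl)C(=O)Nc1ccc(Cl)cn1` gives 3.5. Compound 3 `CCOC[C@H](Oc1ncnc2c1cnn2-c1ncccc1Cl)C(=O)Nc1ccc(C#N)cn1` carries cyano in place of chloro on an aromatic carbon, para to a large group: cyano in place of chloro on an aromatic carbon. Within the data shown here, the only measured step, a number 0.50 log units lower from compound 1 to compound 2 (beyond the scatter), lies on the saturated chain, away from this place, and so serves only as a guide to size. Among the measured compounds shown here, no step at this place has been measured. A modest move to a lower number is nevertheless expected in this assay. The estimated step is a number 0.60 log units lower from compound 2 to compound 3 (beyond the scatter). For compound 3 the expected value is 2.4, with an estimated range from 2 to 2.8.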

Compound 3, distribution coefficient: 2
Compound 3: middle estimate off by 0.40 log units, on the high side; the range from low to high includes it.
By their numbers in this assay, from the lowest: compound 3; then compound 2; then compound 1.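

With cyano in place of chloro on the aromatic carbon para to a large group, this assay gives a number 1.00 log units lower from compound 2 to compound 3 (beyond the scatter) and places compound 3 lowest of the three compounds. The read-out therefore responds to a change at this place, and not only to the change on the saturated chain. Nothing shown here explains the size of this step.

As far as these compounds go, how an amine or a carboxylic acid at this place would read remains open. So does whether the same change would give a similar step on the chain of compound 1.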